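The compounds below may be only part of what the source reports. "The series", "measured", "known", "first", "only" and "open" are said of these compounds alone.

Measured so far:
compound 1 `CCO[C@H]1CC[C@H]2CCN(C)[C@H]2C1`: in an assay on HEK293 cells for antagonist activity at Neuronal acetylcholine receptor; alpha3/beta4 (Rattus norvegicus), read by FLIPR, using a membrane potential dye (on this read-out higher numbers stand for weaker inhibition and lower numbers for stronger inhibition), compound 1 gives a limit, > 300000 nM.
compound 2 `CN1CC[C@@H]2CC[C@H](OCc3ccccc3)C[C@@H]21`: in this assay compound 2 gives a limit, > 300000 nM.

Compound 2 stands at a limit, not at a number. Among the compounds with values here, compound 1 likewise gives only a limit. the limit of > 300000 nM in this assay, at which 2 of the 2 values shown sit, shows the whole measured set sitting at that one limit, so no compound has yet returned a readable value. Within the data shown here, the single step between measured compounds, a step that the two limits leave unreadable from compound 1 to compound 2, has a limit at each end and gives no size in either direction.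

Compound 3 `COCCO[C@H]1CC[C@H]2CCN(C)[C@H]2C1` differs from compound 2 by methoxymethyl in place of phenyl on a saturated chain carbon bound to an oxygen on a saturated carbon. Among the measured compounds shown here, the only measured step touching this position is a step that the two limits leave unreadable from compound 1 to compound 2, and it is unreadable; no step of known size bears on the change. The entering methoxymethyl is closer in kind to the methyl of compound 1 than to the phenyl of compound 2, and both of those compounds sit at the limit. The expected step that the limit leaves unreadable from compound 2 to compound 3 is therefore none beyond the scatter, and compound 3 is most likely to come back as a limit again. Compound 3 is estimated at 600000 nM in this assay, with a range from 150000 nM to 3000000 nM.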

Compound 3, half-maximal inhibitory concentration: > 300000 nM
Compound 3 ended at the assay's limit; the forecaster's own chance of this, stated with the estimate: 85%; the middle value does not contradict the limit.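

Compound 3, like compound 1 and compound 2, gives only a limit, so no step among these three compounds can be read in this assay: the limit of > 300000 nM in this assay, at which 3 of the 3 values shown sit.

The compounds shown leave open whether the methyl, phenyl and methoxymethyl groups differ at all in their inhibition, and what a readable value for this series would be.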